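The source may hold more compounds than are shown below. What is called first, only, known or untested is meant among the compounds shown, and "the series" means these compounds.

Measured so far in an ADME assay on HepG2 cells (Homo sapiens) for cytotoxicity, with a stated time of 72 h; on this read-out lower numbers stand for an effect already at smaller amounts and higher numbers for an effect only at larger amounts of compound:
- compound 1 `Cc1ccc(NC(=O)Nc2cc(C)nc3ccccc23)cc1`: > 25000 nM, a limit of the assay
- compound 2 `Cc1cc(NC(=O)Nc2ccc(OC(F)(F)F)cc2)c2ccccc2n1`: 15000 nM

Among the measured compounds shown here, compound 2 holds the only actual number in this assay, so it can be compared with no other exact value. The other reading is the limit of > 25000 nM in this assay, at which 1 of the 2 values shown sits.

Compound 3 `Cc1cc(NC(=O)Nc2ccc(C(=O)O)cc2)c2ccccc2n1` has not yet been measured. It carries carboxy in place of trifluoromethoxy on an aromatic carbon.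

For the measured compounds named here, one measured step bears on this place, an at least 1.6-fold lower number from compound 1 to compound 2 (0.22 log units; that floor lies within the scatter). It is small and open-ended, and it involves a different exchange, so it offers only a weak guide. No step beyond the scatter is therefore expected, with a slight lean towards higher numbers.

The estimated change is a 1.7-fold higher number from compound 2 to compound 3 (0.22 log units; within the scatter). For compound 3 the expected value is 25000 nM, with an estimated range of 12000 nM to 50000 nM.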

Compound 3, half-maximal effective concentration: > 25000 nM
Compound 3: a limit, no number (the forecaster's own chance of this, stated with the estimate: 65%); the middle value lies on the limit itself.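

In this assay, among the compounds shown here, carboxy in place of trifluoromethoxy on this aromatic carbon, para to a large group, gives an at least 1.6-fold higher number from compound 2 to compound 3 (0.22 log units; that floor lies within the scatter), so the first step at this place is also open-ended. The reading of compound 3 is a limit, as is that of compound 1, which leaves the step between them, carboxy in place of methyl, unreadable. Among the three compounds, only the trifluoromethoxy group of compound 2 goes with an actual number, and limits now make up most of the readings: the limit of > 25000 nM in this assay, at which 2 of the 3 values shown sit.

The compounds shown leave open whether carboxy and methyl differ at all in this assay. They also leave open whether an amine, a nitrile or a longer chain at this place would give an actual number on the shared core.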